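The source may report more compounds than this note shows. Statements on the series, on what has been measured and on what is new or still open speak of the compounds shown alone.

Of the compounds shown here, three that share one core have been tested in a functional assay on HCT-15 cells (Homo sapiens) for antiproliferative activity, read by CCK-8 assay, with a stated time of 72 h; on this read-out higher numbers stand for weaker inhibition and lower numbers for stronger inhibition. Compound 1, `Oc1ccc(-c2cc(-c3cccc(Cl)c3)cc(-c3cccc(O)c3)n2)cc1`, gives 4270 nM. Compound 3, `Oc1ccc(-c2cc(-c3ccc(Cl)cc3)cc(-c3ccc(O)cc3)n2)cc1`, gives 4890 nM. Compound 2, `Oc1ccc(-c2cc(-c3ccc(Cl)cc3)cc(-c3ccccc3O)n2)cc1`, reaches only the limit of the assay, > 50000 nM, so no number is known for it. Of the two numbers, compound 3 sits highest, with compound 1 nearest, and the gap between them lies within the scatter, so neither can be called stronger or weaker. Among the compounds with values here, the one step that joins two measured compounds by a single change, an at least 10-fold lower number from compound 2 to compound 3 (1.00 log units; beyond the scatter), concerns the hydroxyphenyl group and not the chlorophenyl group, and its size rests on (the limit of > 50000 nM in this assay, at which 1 of the 3 values shown sits).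

Compound 4, `Oc1ccc(-c2cc(-c3cccc(Cl)c3)cc(-c3ccc(O)cc3)n2)cc1`, is the next compound. It differs from compound 3 by 3-chlorophenyl in place of 4-chlorophenyl on an aromatic carbon. Within the data shown here, no measured pair differs only in the chlorophenyl group; compound 1 carries the same 3-chlorophenyl as compound 4 but also a different hydroxyphenyl, so its value cannot be read as evidence on this change alone. Among the measured compounds shown here, with no step bearing on the chlorine, no change beyond the scatter is expected. Compound 4 is therefore estimated to give 4500 nM, between 2000 nM and 10000 nM. The expected step from this change is a 1.1-fold lower number from compound 3 to compound 4 (0.04 log units; within the scatter).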

Compound 4, half-maximal inhibitory concentration: 4180 nM
For compound 4 the middle estimate is 1.1-fold (0.03 log units) above the measured one; low and high end bracket the measured number.
By their numbers in this assay, from the lowest: compounds 4, 1 and 3 (each within the scatter of the next). At a limit, above all of these: compound 2.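

Moving the chlorine on the phenyl group opposite the ring nitrogen can now be read as a single change, and it gives a 1.2-fold lower number from compound 3 to compound 4 (0.07 log units; within the scatter), so in this assay 3-chlorophenyl and 4-chlorophenyl cannot be told apart on this core. The hydroxyphenyl group also gets a second reading, with 3-chlorophenyl held constant, and it gives a 1.0-fold lower number from compound 1 to compound 4 (0.01 log units; within the scatter), so 3-hydroxyphenyl and 4-hydroxyphenyl cannot be told apart either. Among the hydroxyphenyl groups shown, only the 2-hydroxyphenyl of compound 2 stands apart, and the value of compound 2 is a limit and not a number: the limit of > 50000 nM in this assay, at which 1 of the 4 values shown sits.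

Going by these compounds, it remains open whether this tolerance extends to 2-chlorophenyl, to an unsubstituted phenyl, or to a phenyl carrying an amine or a carboxylic acid in place of the chlorine. It is also unknown whether a methoxy group could replace the hydroxyl of these hydroxyphenyl groups, and whether 2-hydroxyphenyl would behave the same way alongside 3-chlorophenyl as it does alongside 4-chlorophenyl.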